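The source may report more compounds than this note shows. Statements on the series, on what has been measured and on what is new or still open speak of the compounds shown alone.

Measured compounds:
compound 1, `CC1=C(C(=O)OCC(C)C)C(c2ccoc2)NC(=O)N1`: 326 nM
compound 2, `CCC(C)OC(=O)C1=C(C)NC(=O)NC1c1ccoc1`: 201 nM
compound 3, `CC1=C(C(=O)OC2CCC2)C(c2ccoc2)NC(=O)N1`: 307 nM

These three compounds share one core and differ only in the group on an oxygen next to a carbonyl group. In an assay on membranes from HEK293 cells for displacement of a labelled ligand from adenosine receptor A2b (Homo sapiens), read by scintillation counting, with a stated time of 30 min (a lower number here means a stronger inhibitor, a higher number a weaker inhibitor), compound 3 gives 307 nM, which is the second highest of the three numbers. Its nearest neighbour is compound 1, with a 1.1-fold lower number from compound 1 to compound 3 (0.03 log units; within the scatter), and its furthest is compound 2, with a 1.5-fold higher number from compound 2 to compound 3 (0.18 log units; within the scatter); both gaps sit within the scatter, so no order among the three can be read from them.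

Compound 4, `CC1=C(C(=O)OCC2CC2)C(c2ccoc2)NC(=O)N1`, has not yet been measured. It differs from compound 3 in one place: cyclopropylmethyl in place of cyclobutyl on an oxygen next to a carbonyl group.

All three measured steps bear on this change, since each swaps one small alkyl group for another on the same oxygen: a 1.6-fold lower number from compound 1 to compound 2 (0.21 log units; within the scatter), a 1.1-fold lower number from compound 1 to compound 3 (0.03 log units; within the scatter) and a 1.5-fold higher number from compound 2 to compound 3 (0.18 log units; within the scatter). None of them reaches beyond the scatter. On that basis no step beyond the scatter is expected in this assay for compound 4 either, and the estimated step is a 1.1-fold lower number from compound 3 to compound 4 (0.02 log units; within the scatter). The expected value for compound 4 in this assay is 290 nM, with a range from 140 nM to 600 nM.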

Compound 4, inhibition constant: 426 nM
Compound 4: the middle estimate sits 1.5-fold (0.17 log units) below what was measured; measured number inside the range.
By their numbers in this assay, from the lowest: compounds 2, 3, 1 and 4 (each within the scatter of the next, the first and the last beyond it).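

In this assay, exchanging one ring for another on this oxygen, cyclobutyl for cyclopropylmethyl, stays within the scatter (a 1.4-fold higher number from compound 3 to compound 4 (0.14 log units; within the scatter)), and so does exchanging isobutyl for cyclopropylmethyl (a 1.3-fold higher number from compound 1 to compound 4 (0.12 log units; within the scatter)). Within the data shown here, what is new is the first step beyond the scatter at this position, a modest one, from sec-butyl to cyclopropylmethyl (a 2.1-fold higher number from compound 2 to compound 4 (0.33 log units; beyond the scatter)), which shows that these groups are not all interchangeable here, although compound 1 and compound 3 each remain within the scatter of compound 4 and so no full ranking of the four groups can be drawn. No measurement is available that would explain this one gap.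

From the compounds shown here alone, all four groups are small and made of carbon alone, so what a longer chain, or a group carrying an amine or a carboxylic acid, would do on this oxygen stays open. The shared core is also the same throughout, which leaves open whether the step from sec-butyl to cyclopropylmethyl would keep its size on any other core.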